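Swapping a Long Alkyl Chain for a Short Amine

The source may report more compounds than this note shows. Statements on the series, on what has been measured and on what is new or still open speak of the compounds shown alone.

Measured so far:
compound 1 `CCCCCCCCn1nc(-c2cccnc2)c2ccccc2c1=O` — 21900 nM
compound 2 `CCOC(=O)Cn1nc(-c2cccnc2)c2ccccc2c1=O` — 43700 nM

Among the measured compounds shown here, in a functional assay (trachea) with Cavia porcellus as the target (a higher number here means a weaker inhibitor, a lower number a stronger inhibitor), compound 1 gives 21900 nM, one of only two numbers measured; compound 2 gives 43700 nM, and the two sit within the usual scatter of each other, as the step shows: a 2.0-fold higher number from compound 1 to compound 2 (0.30 log units; within the scatter). Compound 3 `NCCn1nc(-c2cccnc2)c2ccccc2c1=O` has not yet been measured. Compared with compound 1 it carries amino in place of hexyl on a saturated chain carbon, two bonds along the chain from an aromatic nitrogen. For the measured compounds named here, only that one measured step bears on this change, and it was small. A similarly small shift toward a higher number is therefore expected, so compound 3 is estimated at 40000 nM (range 15000 nM to 120000 nM), which means a 1.8-fold higher number from compound 1 to compound 3 (0.26 log units; within the scatter).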

Compound 3, half-maximal inhibitory concentration: > 100000 nM
Compound 3 ended at the assay's limit (the forecaster's own chance of this, stated with the estimate: 20%); middle value at least 2.5-fold (0.39 log units) away from the limit.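

In this assay compound 3 gives > 100000 nM, which is a limit of the assay and not a number. Even so, this position responds to the change: putting amino in place of hexyl gives an at least 4.5-fold higher number from compound 1 to compound 3 (0.65 log units; beyond the scatter), and the comparison with the ester gives an at least 2.2-fold higher number from compound 2 to compound 3 (0.35 log units; beyond the scatter). Compound 1 and compound 2 had stayed within the scatter of each other, so not every replacement here is tolerated equally.

Going by these compounds, the true size of both steps stays open. A longer chain ending in an amine, or a carboxylic acid in place of the ethoxycarbonyl, could help separate the effect of the amine from that of the shorter chain.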